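The source may hold more compounds than are shown below. What is called first, only, known or untested is meant among the compounds shown, and "the series" means these compounds.

Measured so far in an assay on brain (strain C57BL6) for displacement of a labelled ligand from AP2-associated protein kinase 1 (Mus musculus), read by scintillation counting, with a stated time of 1 h; on this read-out higher numbers stand for weaker inhibition and lower numbers for stronger inhibition:
compound 1 `COC(=O)Nc1cc(-c2ccc(OC[C@@](C)(N)CC(C)C)c(C)c2)ccn1`: 0.08 nM
compound 2 `COC(=O)Nc1cc(-c2ccc(OC[C@@](C)(N)CC(C)C)cn2)ccn1`: 18 nM
compound 3 `COC(=O)Nc1cc(-c2cc(C)c(OC[C@@](C)(N)CC(C)C)cn2)ccn1`: 1.4 nM

Compound 1 and compound 2 have different cores; the difference between the two cores is not broken down here. Compound 3 carries methyl in place of hydrogen on an aromatic carbon on the core of compound 2, and the step is a 13-fold lower number from compound 2 to compound 3 (1.11 log units; beyond the scatter). Compound 4 `COC(=O)Nc1cc(-c2ccc(OC[C@@](C)(N)CC(C)C)c(C)c2C)ccn1` carries methyl in place of hydrogen on an aromatic carbon on the core of compound 1. This is the same kind of change, not the same: in compound 3 the methyl sits on a six-membered aromatic ring with 1 nitrogen, ortho to the (2-amino-2,4-dimethylpentyl)oxy group, meta to a large group and opposite the ring nitrogen; in compound 4 it sits on a ring of carbon only, ortho to a large group, ortho to a methyl group and meta to the (2-amino-2,4-dimethylpentyl)oxy group. For compound 4 in this assay a smaller step than a 13-fold lower number from compound 2 to compound 3 (1.11 log units; beyond the scatter) is expected, a 1.3-fold higher number from compound 1 to compound 4 (0.10 log units; within the scatter), because compound 1 already gives 0.08 nM and the surroundings of the place differ. Compound 4 is therefore estimated at 0.1 nM, between 0.03 nM and 0.5 nM.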

Compound 4, inhibition constant: 0.26 nM
Compound 4: middle estimate off by 2.6-fold (0.41 log units), on the low side; the range from low to high includes it.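

Methyl in place of hydrogen on an aromatic carbon gives a 3.3-fold higher number from compound 1 to compound 4 (0.51 log units; beyond the scatter) in this assay, opposite in direction to the earlier step. The change therefore does not carry over as a fixed increment between these two cores: the same change on two cores in this assay, a 13-fold lower number (1.11 log units; beyond the scatter) from compound 2 to compound 3 and a 3.3-fold higher number (0.51 log units; beyond the scatter) from compound 1 to compound 4, 42-fold (1.62 log units) apart, beyond the scatter of two such steps. What this does not show is the source of the gap, since the two pairs differ both in the ring carrying the methyl and in the surroundings of the place, and two steps cannot separate these.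

Open, from the compounds shown here alone, is whether ethyl, fluorine or methoxy at the place changed in compound 4 would follow methyl. Also open, going by these compounds, is whether the step holds with a shorter chain in place of the (2-amino-2,4-dimethylpentyl)oxy group.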